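Cyanoguanidine series: swapping the alkyl group on the imine nitrogen

The source may report more compounds than this note shows. Statements on the series, on what has been measured and on what is new or still open speak of the compounds shown alone.

Measured so far:
compound 1 `CCC/N=C(\NC#N)Nc1cc(C(F)(F)F)cc(C(F)(F)F)c1` gives 12400 nM in a functional assay (aorta) with Rattus norvegicus as the target; a lower number here means a stronger inhibitor, a higher number a weaker inhibitor
compound 2 `C[C@H](/N=C(\NC#N)Nc1cc(C(F)(F)F)cc(C(F)(F)F)c1)C(C)(C)C` gives 11900 nM in this assay
compound 3 `C[C@@H](/N=C(\NC#N)Nc1cc(C(F)(F)F)cc(C(F)(F)F)c1)C(C)(C)C` gives 20300 nM in this assay

The three measured compounds share a core and differ only in the group on the double-bonded nitrogen. Compound 3 stands at the top of the three numbers, yet every gap to it is within the scatter: a 1.6-fold higher number from compound 1 to compound 3 (0.21 log units; within the scatter) and a 1.7-fold higher number from compound 2 to compound 3 (0.23 log units; within the scatter). Compounds 2 and 3 differ only in configuration (the fact that compounds 2 and 3 differ only in the configuration as drawn), and the change from propyl to the branched chain, a 1.0-fold lower number from compound 1 to compound 2 (0.02 log units; within the scatter), also stays within the scatter.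

Compound 4 `N#CN/C(=N\C1CCCC1)Nc1cc(C(F)(F)F)cc(C(F)(F)F)c1` has not been measured. It differs from compound 3 as follows: cyclopentyl in place of 1,2,2-trimethylpropyl on a double-bonded nitrogen. The two measured steps that alter the same position, from compound 1 to compound 2 and from compound 1 to compound 3, both left the number within the scatter, so no step beyond the scatter is expected here either.

Compound 4 is therefore estimated at 15000 nM, with a range from 6000 nM to 40000 nM, which is an expected step of a 1.4-fold lower number from compound 3 to compound 4 (0.13 log units; within the scatter).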

Compound 4, half-maximal inhibitory concentration: > 300000 nM
Compound 4 was reported as a limit; the forecaster's own chance of this, stated with the estimate: 10%; middle value at least 20-fold (1.30 log units) away from the limit.
By their numbers in this assay, from the lowest: compounds 2, 1 and 3 (each within the scatter of the next). At a limit, above all of these: compound 4.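

Compound 4 is reported only as a limit and not as a number: the limit of > 300000 nM in this assay, at which 1 of the 4 values shown sits. For the compounds shown here, the group on the double-bonded nitrogen had so far made no difference beyond the scatter, but this position is not indifferent to what sits there: cyclopentyl gives an at least 14-fold higher number from compound 3 to compound 4 (1.16 log units; beyond the scatter), an at least 25-fold higher number from compound 2 to compound 4 (1.40 log units; beyond the scatter) and an at least 24-fold higher number from compound 1 to compound 4 (1.38 log units; beyond the scatter). Compound 4 is the only one of the four with a ring at this place, so the change that matters here is one from an open chain to a ring, although a single compound cannot show that the ring itself is what counts.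

From the compounds shown here alone, whether a cyclobutyl or cyclohexyl group, or an open pentyl chain, on this nitrogen would behave like cyclopentyl or like propyl remains open. Going by these compounds, the true size of these steps also remains open, as they rest on a limit.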